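Aminoethoxy phenyl in place of the fluorinated phenyl

The source may report more compounds than this note shows. Statements on the series, on what has been measured and on what is new or still open speak of the compounds shown alone.

In a physicochemical assay for solubility, read by HPLC, using the shake flask method, in phosphate buffer, with a stated time of 20 h, at pH 6.5 (a higher number here means a more soluble compound, a lower number a less soluble compound), compound 1 (`CN1CCN(CC2CCN(c3nccc4[nH]c(-c5ccc(F)c(F)c5)nc34)CC2)CC1`) gives 195000 nM and compound 2 (`CN1CCN(CC2CCN(c3nccc4[nH]c(-c5cc(F)cc(C(F)(F)F)c5)nc34)CC2)CC1`) gives 165000 nM. For the measured compounds named here, these two values lie within the scatter of each other, so compound 2 stands level with its only measured neighbour.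

Compound 3 (`CN1CCN(CC2CCN(c3nccc4[nH]c(-c5cccc(OCCN)c5)nc34)CC2)CC1`) carries 3-(2-aminoethoxy)phenyl in place of 3-fluoro-5-(trifluoromethyl)phenyl, on an aromatic carbon of the five-membered aromatic ring with 2 nitrogen, between two ring nitrogen atoms: 3-(2-aminoethoxy)phenyl in place of 3-fluoro-5-(trifluoromethyl)phenyl on an aromatic carbon.

Going by the values given here, one measured step bears on this change, a 1.2-fold lower number from compound 1 to compound 2 (0.07 log units; within the scatter). Among the compounds with values here, that step exchanges one fluorinated phenyl for another, and no measured compound carries the entering group, so it offers only a weak guide. In this assay no step beyond the scatter is therefore expected, though the uncertainty is wide and extends further on the upper side. The expected step is a 1.4-fold higher number from compound 2 to compound 3 (0.14 log units; within the scatter).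

For compound 3 the estimated value is 230000 nM, with an expected range of 110000 nM to 500000 nM.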

Compound 3, solubility: 200000 nM
The estimate for compound 3 lay 1.2-fold (0.06 log units) above the measured number; the measured number falls inside the stated range.
By their numbers in this assay, from the lowest: compounds 2, 1 and 3 (each within the scatter of the next).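

In this assay the exchange of 3-fluoro-5-(trifluoromethyl)phenyl for 3-(2-aminoethoxy)phenyl on an aromatic carbon gives a 1.2-fold higher number from compound 2 to compound 3 (0.08 log units; within the scatter), and the exchange of 3,4-difluorophenyl for the same group gives a 1.0-fold higher number from compound 1 to compound 3 (0.01 log units; within the scatter). The earlier compounds shown here compared only fluorinated phenyl groups at this place, between two ring nitrogen atoms; compound 3 extends the comparison to a phenyl with an aminoethoxy chain, which carries a hydrogen-bond donor and acceptors where 3-fluoro-5-(trifluoromethyl)phenyl has none, and all three compounds still stand level in this read-out. No measured evidence accompanies these numbers that would account for their standing level.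

Whether the amine at the end of the chain matters stays open: the compounds shown do not tell how a phenyl carrying a carboxylic acid, a dimethylamine or a longer chain would read at this place. On these data alone, a pyridine in place of the phenyl is also untested among them, and all of these comparisons rest on this one read-out alone, so how the exchange behaves in any other measurement remains unknown.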